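The source may report more compounds than this note shows. Statements on the series, on what has been measured and on what is new or still open speak of the compounds shown alone.

Working notes on the aryl-alkyne series.

Compound 1 `COc1ccccc1C#Cc1cc(Cl)ccc1OCC(=O)O` gives 190 nM in an assay on CHO cells for displacement of a labelled ligand from prostaglandin D2 receptor 2 (Homo sapiens), read by scintillation counting; a higher number here means a weaker inhibitor, a lower number a stronger inhibitor. Among the compounds with values here, compound 2 `O=C(O)COc1ccc(Cl)cc1C#Cc1ccccc1Cl` gives 28 nM, the second highest of the three numbers so far. Compound 3 `CS(=O)(=O)c1ccc(Cl)c(C#Cc2cc(Cl)ccc2OCC(=O)O)c1` gives 3.5 nM. The two measured steps are a 6.8-fold lower number from compound 1 to compound 2 (0.83 log units; beyond the scatter) and an 8.0-fold lower number from compound 2 to compound 3 (0.90 log units; beyond the scatter); both are modest and both lie beyond the scatter, and both alter what is attached to the ring that is joined to the triple-bonded carbon.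

Compound 4 `O=C(O)COc1ccc(Cl)cc1C#Cc1ccc(Cl)cc1` has not been measured. It differs from compound 2 by 4-chlorophenyl in place of 2-chlorophenyl on a triple-bonded carbon. Here nothing leaves and nothing enters in terms of atom count: the two structures have the same atoms, joined differently. Neither measured step tests such a rearrangement, since compound 1 to compound 2 swaps one group for another at an unchanged place and compound 2 to compound 3 adds a group. The data therefore give no direct guide; a step of at most modest size is expected, somewhat more likely toward a higher number, with a real chance that it stays within the scatter.

Compound 4 is estimated at 70 nM, within 20 nM to 250 nM, meaning an expected step of a 2.5-fold higher number from compound 2 to compound 4 (0.40 log units; beyond the scatter).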

Compound 4, inhibition constant: 60 nM
Beside the measured number, compound 4's estimate is 1.2-fold (0.07 log units) above it; low and high end bracket the measured number.
By their numbers in this assay, from the lowest: compound 3; then compound 2; then compound 4; then compound 1.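

Replacing 2-chlorophenyl with 4-chlorophenyl on the triple-bonded carbon gives a 2.1-fold higher number from compound 2 to compound 4 (0.33 log units; beyond the scatter) in this assay. The earlier steps shown here swapped one group for another or added a group, whereas here the atoms stay the same and only their arrangement changes, so this position responds to where the chlorine sits as well as to which group is present. Nothing available accounts for this difference.

Still open, on these data alone, is how a plain phenyl, or a ring bearing a nitrile or an amine, would compare with 2-chlorophenyl and 4-chlorophenyl on the triple-bonded carbon. Within the data shown here, also open is whether methylsulfonyl, added to compound 4 in place of hydrogen on the aromatic carbon where it sits in compound 3, would give a step of similar size to the one it gives from compound 2.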